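The source may report more compounds than this note shows. Statements on the series, on what has been measured and on what is new or still open speak of the compounds shown alone.

Measured so far:
compound 1 `O=C(NCCNS(=O)(=O)c1cc(-c2ccccc2Oc2ccc(O)c(O)c2)cs1)Nc1cc(C(F)(F)F)cc(C(F)(F)F)c1` — 1300 nM
compound 2 `Cc1ccc(-c2ccsc2S(=O)(=O)NCCNC(=S)Nc2cc(C(F)(F)F)cc(C(F)(F)F)c2)c(Oc2ccc(O)c(O)c2)c1` — 3200 nM

Working notes. In a functional assay on HL-60 cells (Homo sapiens) for inhibition, read by CCK-8 assay, with a stated time of 48 h (a higher number here means a weaker inhibitor, a lower number a stronger inhibitor), compound 2 gives 3200 nM, the highest of the two numbers in hand. Among the measured compounds shown here, the only other measured compound, compound 1, gives 1300 nM, a lower number, and the gap between the two lies beyond the usual scatter; no single-point step joins them, so the two values are taken only as they stand.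

Compound 3 `O=S(=O)(NCCNC(=S)Nc1cc(C(F)(F)F)cc(C(F)(F)F)c1)c1sccc1-c1ccccc1Oc1ccc(O)c(O)c1` is not yet measured. It differs from compound 2 in one place: hydrogen in place of methyl on an aromatic carbon. The removed group is a single carbon without ring, donors or acceptors, and nothing in the measured pair speaks to this change. The expected step in this assay is therefore small, with no direction favoured, and is estimated as a 1.1-fold lower number from compound 2 to compound 3 (0.03 log units; within the scatter). Compound 3 is expected to give about 3000 nM, with a range from 1400 nM to 6500 nM.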

Compound 3, half-maximal inhibitory concentration: 4300 nM
Compound 3: the middle estimate sits 1.4-fold (0.16 log units) below what was measured, within the range that was stated.
By their numbers in this assay, from the lowest: compound 1; then compounds 2 and 3 (each within the scatter of the next).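

In this assay, among the compounds shown here, the change from methyl to hydrogen on this aromatic carbon, meta to a 3,4-dihydroxyphenoxy group and para to a large group, gives a 1.3-fold higher number from compound 2 to compound 3 (0.13 log units; within the scatter) and so provides the first one-place comparison. At this position, the methyl can therefore be lost without a step that stands clear of the scatter, although this rests on a single pair. No independent measurement bears on the reading of this step.

Still open, going by these compounds, is whether a larger or differently functional group on this carbon, such as a methoxy, an amine, a carboxylic acid or a longer chain such as ethyl, would give a step beyond the scatter. Compound 1 differs from both compounds in more than one place, so its gap to them cannot be read as the effect of any single change.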